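The compounds below may be only part of what the source reports. "The series", "measured", "known", "first", "only" and "open" are said of these compounds alone.

In a functional assay on a cell-free system (plasma, Oryctolagus cuniculus) for inhibition, with stated times of 5 min, 1 min and 6 min (on this read-out higher numbers stand for weaker inhibition and lower numbers for stronger inhibition), compound 1 (`CCOC(=O)c1c(C)nc(-c2cccc(C#N)c2)n1C(C)C`) gives 9260 nM. Compound 2 (`CCOC(=O)c1c(C)nc(-c2cccc(C#N)c2)n1OCC(N)=O`) stands at > 30000 nM, which is a limit of the assay and not a number. That reading is the limit of > 30000 nM in this assay, at which 1 of the 2 values shown sits. Going by the values given here, the only measured step is an at least 3.2-fold higher number from compound 1 to compound 2 (0.51 log units; beyond the scatter), and its true size remains open, since one end of it is a limit. Compound 3 (`CCOC(=O)c1c(C)nc(-c2cccc(C#N)c2)n1OCc1ccccc1F`) carries 2-fluorophenyl in place of carbamoyl on a saturated chain carbon bound to an oxygen on an aromatic ring. Among the compounds with values here, no measured step covers this exchange directly, so the expectation rests on a single comparison. Compound 1, which has no carbamoyl, has a measured number at 9260 nM, and the loss of the carbamoyl is therefore expected to move the reading in this assay towards a lower number, meaning stronger inhibition, by a step of about the size seen between the two measured compounds. The expected change is an at least 3.3-fold lower number from compound 2 to compound 3 (0.52 log units; beyond the scatter). For compound 3 the estimate is 9000 nM, with an expected range of 2500 nM to 30000 nM.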

Compound 3, half-maximal inhibitory concentration: 8990 nM
Estimate against measurement, compound 3: 1.0-fold (0.00 log units) above; low and high end bracket the measured number.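

On the chain carried by this aromatic nitrogen, replacing the carbamoyl end group with 2-fluorophenyl gives an at least 3.3-fold lower number from compound 2 to compound 3 (0.52 log units; beyond the scatter) in this assay, so the weak reading of compound 2 does not follow from the oxygen-linked chain alone. The comparison with the isopropyl compound adds that (2-fluorobenzyl)oxy, which brings a six-membered aromatic ring to this position, is matched in this assay by the much simpler group, with a 1.0-fold lower number from compound 1 to compound 3 (0.01 log units; within the scatter), so the two stand level within the scatter. The reading of compound 2 is a limit of the assay and not a number, and how far the carbamoyl compound lies from the other two remains unknown because of this: the limit of > 30000 nM in this assay, at which 1 of the 3 values shown sits.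

The compounds shown leave open whether the fluorine has any part in the reading of compound 3, which a plain benzyl group on the same oxygen would address. They also leave open whether an amine or a carboxylic acid at the end of the chain would read like the carbamoyl or like the 2-fluorophenyl compound.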